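A Thiophene Ring in Place of an Ether Group

This account rests on a few compounds, and the source may have more. Where it says the series, first, only, none or still open, it means among the compounds named here.

Compound 3 `Cc1[nH]c2ccc(OC(C)C)cc2c1C1=CCNCC1` gives 100 nM in an assay on HEK293 cells for displacement of a labelled ligand from 5-hydroxytryptamine receptor 6 (Homo sapiens), read by scintillation counting, with a stated time of 1 h (on this read-out higher numbers stand for weaker inhibition and lower numbers for stronger inhibition), and holds the highest of the three numbers. Compound 1 `Cc1[nH]c2ccc(OS(=O)(=O)C(F)(F)F)cc2c1C1=CCNCC1` gives 50 nM in this assay, and compound 2 `Cc1[nH]c2ccc([N+](=O)[O-])cc2c1C1=CCNCC1` gives 10 nM. The step of a 2.0-fold higher number from compound 1 to compound 3 (0.30 log units; within the scatter) is within the scatter, while a 10-fold higher number from compound 2 to compound 3 (1.00 log units; beyond the scatter) lies beyond it, as does a 5.0-fold lower number from compound 1 to compound 2 (0.70 log units; beyond the scatter). Compound 4 `Cc1[nH]c2ccc(-c3ccsc3)cc2c1C1=CCNCC1` differs from compound 3 by thiophen-3-yl in place of isopropoxy on an aromatic carbon. Among the measured compounds shown here, no measured step exchanges a substituent for an aromatic ring at this position, so the two steps ending at compound 3 guide only loosely. A moderate move toward lower numbers, roughly the size of the step between compound 3 and compound 1, is expected; thus the estimated step is a 2.5-fold lower number from compound 3 to compound 4 (0.40 log units; beyond the scatter). Compound 4 is expected to give about 40 nM in this assay, within a range from 10 nM to 160 nM.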

Compound 4, half-maximal inhibitory concentration: 700 nM
The estimate for compound 4 lay 18-fold (1.24 log units) below the measured number; the measured number lies above the stated range.
By their numbers in this assay, from the lowest: compound 2; then compounds 1 and 3 (each within the scatter of the next); then compound 4.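

Thiophen-3-yl, the one aromatic ring shown on this aromatic carbon, raises the number against every earlier substituent: against isopropoxy (a 7.0-fold higher number from compound 3 to compound 4 (0.85 log units; beyond the scatter)), against ((trifluoromethyl)sulfonyl)oxy (a 14-fold higher number from compound 1 to compound 4 (1.15 log units; beyond the scatter)) and against nitro (a 70-fold higher number from compound 2 to compound 4 (1.85 log units; beyond the scatter)). The number at this position can therefore climb well past the span of the three earlier compounds. Nothing available accounts for this rise. From the compounds shown here alone, whether it belongs to thiophen-3-yl alone or to aromatic rings here generally stays open, as does what an amine or a carboxylic acid would give on this carbon.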